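From pyridin-2-yl to 5-methyl-1,2-oxazol-3-yl on an Amide

The source may report more compounds than this note shows. Statements on the series, on what has been measured and on what is new or still open speak of the compounds shown alone.

Three compounds have been measured in a functional assay on HepG2 cells (Homo sapiens) for cytotoxicity, read by sulforhodamine B assay, with a stated time of 48 h (a lower number here means a stronger inhibitor of growth, a higher number a weaker inhibitor of growth), and each value is a limit of the assay rather than a number:

Compound 1 `Cc1cnc(NC(=O)COc2ccc(/C=C3\SC(=O)NC3=O)cc2)s1`: < 100000 nM
Compound 2 `O=C(COc1ccc(/C=C2\SC(=O)NC2=O)cc1)Nc1ncc([N+](=O)[O-])s1`: < 100000 nM
Compound 3 `O=C(COc1ccc(/C=C2\SC(=O)NC2=O)cc1)Nc1ccccn1`: < 100000 nM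

Compound 3 therefore stands only at a limit in this assay. All three values sit at the same limit (the limit of < 100000 nM in this assay, at which 3 of the 3 values shown sit). The steps a step that the two limits leave unreadable from compound 1 to compound 2, a step that the two limits leave unreadable from compound 1 to compound 3 and a step that the two limits leave unreadable from compound 2 to compound 3 are unreadable in size for that reason. Compound 4 `Cc1cc(NC(=O)COc2ccc(/C=C3\SC(=O)NC3=O)cc2)no1` differs from compound 3 by 5-methyl-1,2-oxazol-3-yl in place of pyridin-2-yl on an amide-type nitrogen. For the measured compounds named here, no measured step bears readably on this change, so neither size nor direction can be drawn from the data. Compound 4 is expected to give about 60000 nM, within 10000 nM to 150000 nM, most likely again reported as a limit. The expected step is a step that the limit leaves unreadable from compound 3 to compound 4.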

Compound 4, concentration for 50% growth inhibition: < 100000 nM
Compound 4 was reported as a limit; the forecaster's own chance of this, stated with the estimate: 75%; the middle value lies beyond the limit too.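

Compound 4 sits at the same assay limit as compound 1, compound 2 and compound 3, so none of its steps to them can be read: the limit of < 100000 nM in this assay, at which 4 of the 4 values shown sit.

Whether the groups on the amide-type nitrogen of these compounds differ at all in this assay remains open.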